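Benzyl in Place of Aryl Carbonyl: Cytotoxicity Outlook

A few compounds are considered here, and "the series" means these few. Any claim that something is new, unique, unknown or untested is made for them only; others in the source may bear on it.

Compound 2 `O=C1COCCN1c1ccc(/N=C\c2cn(C(=O)c3ccc(Cl)cc3)c3ccccc23)cc1` was examined in an ADME assay on BV-2 cells (Mus musculus) for cytotoxicity, read by MTT assay, with a stated time of 48 h, tested at 20 uM (on this read-out higher numbers stand for a weaker effect at the one concentration tested and lower numbers for a stronger effect), where compound 2 gives 99%. Among the two measured numbers this is the lowest; its nearest neighbour is compound 1 `O=C1COCCN1c1ccc(/N=C\c2c[nH]c3ccccc23)cc1`, which in this assay gives 104%, a gap that lies within the scatter. Among the compounds with values here, the single measured step, a number 5 percentage points lower from compound 1 to compound 2 (within the scatter), put (4-chlorophenyl)carbonyl in place of hydrogen on an aromatic nitrogen and did not move the read-out beyond the scatter. Compound 3 `O=C1COCCN1c1ccc(/N=C\c2cn(Cc3ccccc3)c3ccccc23)cc1` has not been measured; it differs from compound 2 by benzyl in place of (4-chlorophenyl)carbonyl on an aromatic nitrogen. This is a second change at the same aromatic nitrogen. Because a number 5 percentage points lower from compound 1 to compound 2 (within the scatter) stayed within the scatter, no step beyond the scatter is expected for compound 3 in this assay either, and the expected step is a number 1 percentage points higher from compound 2 to compound 3 (within the scatter). Compound 3 is therefore estimated at 100%, with a range from 85% to 115%.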

Compound 3, a percentage reported as activity, at one concentration (the size of the read-out at that concentration, not a potency): 87.8%
Beside the measured number, compound 3's estimate is 12.2 percentage points above it; the measured number falls inside the stated range.
By their numbers in this assay, from the lowest: compound 3; then compounds 2 and 1 (each within the scatter of the next).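

In this assay, the aromatic nitrogen now shows a step beyond the scatter: benzyl in place of (4-chlorophenyl)carbonyl gives a number 11.2 percentage points lower from compound 2 to compound 3 (beyond the scatter), and benzyl in place of hydrogen gives a number 16.2 percentage points lower from compound 1 to compound 3 (beyond the scatter). The earlier change at this nitrogen, (4-chlorophenyl)carbonyl in place of hydrogen, had stayed within the scatter, so the read-out does respond to what this position carries, and of the groups shown there only benzyl separates from the others, by a modest margin. No measurement bears on why benzyl differs from the other two groups here.

The compounds shown leave open whether a smaller group such as methyl on the same aromatic nitrogen would also lower the number. They also leave open whether a 4-chlorobenzyl group there would go further than benzyl or fall back within the scatter.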